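Cyclopentyl in place of propyl on compound 3

A few compounds are considered here, and "the series" means these few. Any claim that something is new, unique, unknown or untested is made for them only; others in the source may bear on it.

Measured in a physicochemical assay for solubility, read by HPLC, in phosphate buffer, measured as kinetic solubility, at pH 7.4; on this read-out lower numbers stand for lower solubility and higher numbers for higher solubility:
compound 1 `CCOC(=O)c1cc(-c2ccc(F)cc2)n(-c2ccc(S(N)(=O)=O)cc2)c1C`: 12600 nM
compound 2 `CCCc1cc(-c2ccccc2)n(-c2ccc(S(N)(=O)=O)cc2)c1C`: 3800 nM
compound 3 `CCCC(=O)c1cc(-c2ccc(S(N)(=O)=O)cc2)n(-c2ccc(Cl)cc2)n1`: 25800 nM

Compound 3 holds the highest of the three numbers, and its gaps to compound 1 and compound 2 both lie beyond the scatter. Compound 4 `NS(=O)(=O)c1ccc(-c2cc(C(=O)C3CCCC3)nn2-c2ccc(Cl)cc2)cc1` carries cyclopentyl in place of propyl on a carbonyl carbon. Among the measured compounds shown here, no measured pair shows a change at this place, so the expectation rests on the structural change alone. A moderate step to a lower number is expected in this assay, close to the edge of the scatter. The estimated step is a 2.2-fold lower number from compound 3 to compound 4 (0.33 log units; beyond the scatter). For compound 4 the estimated value is 12000 nM, with an expected range of 4500 nM to 28000 nM.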

Compound 4, solubility: 4600 nM
Estimate against measurement, compound 4: 2.6-fold (0.42 log units) above, and the stated range covers the measured number.
By their numbers in this assay, from the lowest: compounds 2 and 4 (each within the scatter of the next); then compound 1; then compound 3.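

The carbonyl carbon now has its first measured single change: in this assay, cyclopentyl in place of propyl gives a 5.6-fold lower number from compound 3 to compound 4 (0.75 log units; beyond the scatter). This position therefore responds on this read-out, even though the swap leaves hydrogen-bond donors, hydrogen-bond acceptors and net charge unchanged. Nothing at hand accounts for the step.

One pair cannot separate the effect of the ring from that of the added carbons. Open-chain pentyl or smaller cyclopropyl on the same carbonyl carbon would address this, while a chain ending in an amine remains an open case.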